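A few compounds are considered here, and "the series" means these few. Any claim that something is new, unique, unknown or untested is made for them only; others in the source may bear on it.

Measured so far, in a functional assay (aorta) with Rattus norvegicus as the target; a lower number here means that less compound is needed, a higher number that more compound is needed for the effect:

- compound 1, `COc1ccc(-c2nc(/N=C(\N)NC3CCCCC3)sc2-c2ccc(OC)cc2)cc1`, gives > 100 uM.
- compound 2, `C/N=C(/NC)Nc1nc(-c2ccc(OC)cc2)c(-c2ccc(OC)cc2)s1`, gives 2.4 uM.
- compound 3, `COc1ccc(-c2nc(CNC(=O)NC(C)C)sc2-c2ccc(OC)cc2)cc1`, gives 5.7 uM.

For compound 1 the value given is a limit of this assay and not a number; this is the limit of > 100 uM in this assay, at which 1 of the 3 values shown sits. Compound 1 therefore stands at the weak end of the three, where only a bound and no measured concentration is known.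

Compound 4, `COc1ccc(-c2nc(/C=C/C(=O)O)sc2-c2ccc(OC)cc2)cc1`, is not yet measured. It differs from compound 1 in one place: a group of 5 heavy atoms (3 carbon, 2 oxygen; no ring) in place of a group of 10 heavy atoms (7 carbon, 3 nitrogen; one six-membered non-aromatic ring of carbon only), on an aromatic carbon.

Two measured steps start from the same compound 1 and change the same group on the same aromatic carbon. In the first, an at least 41-fold lower number from compound 1 to compound 2 (1.61 log units; beyond the scatter). In the second, an at least 17-fold lower number from compound 1 to compound 3 (1.24 log units; beyond the scatter). Both replace the large ring-bearing group with a smaller chain and both give a large lowering of the number, while between the two smaller groups themselves the difference is only modest, as a 2.4-fold higher number from compound 2 to compound 3 (0.38 log units; beyond the scatter) shows. Compound 4 also exchanges that large group for a small chain, so a large lowering is expected here as well, an at least 6.6-fold lower number from compound 1 to compound 4 (0.82 log units; beyond the scatter). Compound 4 is thus expected to give about 15 uM, with a likely range from 3 uM to 80 uM.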

Compound 4, concentration for half-maximal effect: 55 uM
Compound 4: middle estimate off by 3.7-fold (0.56 log units), on the low side, within the range that was stated.
By their numbers in this assay, from the lowest: compound 2; then compound 3; then compound 4. At a limit, above all of these: compound 1.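

The two small groups seen earlier lay only a modest step apart, but on this aromatic carbon 2-carboxyethenyl separates clearly from both in this assay, with a 9.6-fold higher number from compound 3 to compound 4 (0.98 log units; beyond the scatter) and with a 23-fold higher number from compound 2 to compound 4 (1.36 log units; beyond the scatter). Exchanging the large ring-bearing group for a small chain is therefore not enough on its own to reach the low numbers of compound 2 and compound 3, and this change reads as an at least 1.8-fold lower number from compound 1 to compound 4 (0.25 log units; that floor lies within the scatter), which does not establish a lowering beyond the scatter. The value of compound 1 is a limit and not a number, so the true size of this step stays unknown: the limit of > 100 uM in this assay, at which 1 of the 4 values shown sits.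

On these data alone, it remains open whether the higher number of compound 4 goes with the carboxylic acid itself or with the double bond in its chain, which a saturated propanoic acid chain or a methyl ester on the same carbon would help to separate. Also open, as far as these compounds go, is whether the nitrogen atoms in the groups of compound 2 and compound 3 matter for their lower numbers, a question that a short chain ending in an amine could address.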